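This account rests on a few compounds, and the source may have more. Where it says the series, first, only, none or still open, it means among the compounds named here.

Measured compounds:
- compound 1, `Cc1cnn(C(=O)NCc2ccc(OCc3ccccc3)cc2)c1`: > 100000 nM
- compound 2, `Cc1cnn(C(=O)N2CCCN(Cc3ccc(OCc4ccccc4)cc3)CC2)c1`: > 100000 nM
- compound 3, `Cc1cnn(C(=O)N(C)CCN(C)Cc2ccc(OCc3ccccc3)cc2)c1`: > 100000 nM

All three share the benzyloxy-benzyl portion and the carbonyl-linked 4-methyl-1H-pyrazol-1-yl end, differing only in the linker between them. In an assay on membranes from brain for binding affinity to neutral cholesterol ester hydrolase 1 (Mus musculus), read by fluorescence, with stated times of 1 h and 30 min (on this read-out higher numbers stand for weaker inhibition and lower numbers for stronger inhibition), compound 1 returns > 100000 nM, which is a limit of the assay and not a number. Compound 2 returns > 100000 nM in this assay, again a limit. Compound 3 returns > 100000 nM in this assay, also a limit. Compound 3 therefore stands nowhere distinct on these numbers: all three values sit at the limit of > 100000 nM in this assay, at which 3 of the 3 values shown sit, and no ordering among them can be read.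

Compound 4, `CN(CCN(C)C(=O)n1cccn1)Cc1ccc(OCc2ccccc2)cc1`, is the next compound to be measured. It differs from compound 3 by hydrogen in place of methyl on an aromatic carbon, in words hydrogen in place of methyl on an aromatic carbon. No measured step is recorded for any change of this kind in the series, and the only values at hand are limits. With three of three compounds at the assay limit, the expectation is that compound 4 likewise shows no measurable inhibition, so the expected step that the limit leaves unreadable from compound 3 to compound 4 amounts to none beyond the scatter. Compound 4 is accordingly estimated at 150000 nM, with a range of 50000 nM to 500000 nM, and most likely reported only as a limit.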

Compound 4, half-maximal inhibitory concentration: > 100000 nM
Compound 4: no number, only a limit (the forecaster's own chance of this, stated with the estimate: 85%); the middle value is on the limit's open side.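

No step can be read from compound 3 to compound 4 for hydrogen in place of methyl on an aromatic carbon, as both values are limits in this assay: the limit of > 100000 nM in this assay, at which 4 of the 4 values shown sit.

The compounds shown leave open which structural change, if any, would give a measurable value in this assay.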